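This account rests on a few compounds, and the source may have more. Where it says the series, first, only, none or still open, it means among the compounds named here.

The series rests on a shared core carrying a sulfonyl-linked aryl group and a substituted piperidine. Compound 1 `CC1CCN(c2c(S(=O)(=O)c3ccc(F)c(Cl)c3)cnc3cc(Cl)ccc23)CC1` and compound 2 `CC1CCN(c2c(S(=O)(=O)c3ccc(F)c(Cl)c3)cnc3cc(F)ccc23)CC1` differ only in a halogen on the core. In an assay on isolated protein for displacement of a labelled ligand from metabotropic glutamate receptor 5 (Homo sapiens), with a stated time of 60 min, tested at 1 uM (on this read-out higher numbers stand for more inhibition at the one concentration tested (going by the name of the read-out) and lower numbers for less inhibition), compound 1 gives 94%, and compound 2 gives 94%, so the step of no change at the digits printed from compound 1 to compound 2 (within the scatter) shows that this halogen exchange leaves the read-out where it was. Compound 3 `COCC1CCN(c2c(S(=O)(=O)c3cc(F)cc(F)c3)cnc3cc(F)ccc23)CC1` is not a single-point change from compound 2. In this assay compound 3 gives 83%, a lower number beyond the scatter. Compound 2 therefore stands level with compound 1 at the top of the three numbers, with compound 3 as the furthest.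

Compound 4 `CC1CCN(c2c(S(=O)(=O)c3ccc(Cl)cc3)cnc3cc(F)ccc23)CC1` is reached from compound 2 by 4-chlorophenyl in place of 3-chloro-4-fluorophenyl on a sulfonyl sulfur. For the measured compounds named here, no measured step changes this aryl group itself; the only single-point step available, no change at the digits printed from compound 1 to compound 2 (within the scatter), concerns a halogen on the core and produced no change beyond the scatter. The removal of one fluorine on the sulfonyl-bound ring is thus untested, and the account takes the flat step no change at the digits printed from compound 1 to compound 2 (within the scatter) as the nearest guide while allowing for a modest loss. Compound 4 is expected to give 89% in this assay, with a range from 76% to 98%. The expected step is a number 5 percentage points lower from compound 2 to compound 4 (within the scatter), which is estimated to stay inside the scatter.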

Compound 4, a percentage reported as inhibition, at one concentration (the size of the read-out at that concentration, not a potency): 90%
The estimate for compound 4 lay 1 percentage points below the measured number; the range from low to high includes it.
By their numbers in this assay, from the lowest: compounds 3, 4, 1 and 2 (each within the scatter of the next, the first and the last beyond it).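

Where the earlier pair spoke only to a halogen on the core, this pair speaks to the aryl group on the sulfonyl sulfur: in this assay, 4-chlorophenyl in place of 3-chloro-4-fluorophenyl gives a number 4 percentage points lower from compound 2 to compound 4 (within the scatter). At this position, then, the read-out does not separate the two aryl groups, and in this pair the single chlorine of 4-chlorophenyl holds up as well as the chlorine and fluorine of 3-chloro-4-fluorophenyl, just as the halogen exchange on the core gave no change at the digits printed from compound 1 to compound 2 (within the scatter). Nothing measured here bears on why the read-out holds across this change.

As far as these compounds go, whether the aryl group on the sulfonyl sulfur keeps the read-out with no halogen at all, or with an amine or a carboxylic acid in place of the halogens, stays open. With every number taken at a single concentration, the compounds shown also cannot tell whether compound 2 and compound 4 would separate on a measure of potency.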